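This account rests on a few compounds, and the source may have more. Where it says the series, first, only, none or still open, it means among the compounds named here.

For the measured compounds named here, in a functional assay on EBC-1 cells (Homo sapiens) for antiproliferative activity, with a stated time of 72 h (on this read-out lower numbers stand for stronger inhibition and higher numbers for weaker inhibition), compound 1 `Cn1cc(-c2cn3c(Cc4ccc5ncccc5c4)cnc3cc2Cl)cn1` stands as "not determined" (no result reported) without a number, and compound 2 `OCCn1cc(-c2cc(F)c3ncc(Cc4ccc5ncccc5c4)n3c2)cn1` gives 0.34 nM as the only value, so it has nothing to be ranked against. Compound 3 `CNC(=O)c1cccc(-c2cc(F)c3ncc(Cc4ccc5ncccc5c4)n3c2)c1` differs from compound 2 by one change 3-(methylcarbamoyl)phenyl in place of 1-(2-hydroxyethyl)-1H-pyrazol-4-yl on an aromatic carbon. Going by the values given here, no measured step exists to guide this change, and the expected 5.9-fold higher number from compound 2 to compound 3 (0.77 log units; beyond the scatter) is towards weaker inhibition, modest in size. Compound 3 is expected at 2 nM with an estimated range from 0.4 nM to 12 nM in this read-out.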

Compound 3, half-maximal inhibitory concentration: 400 nM
Estimate against measurement, compound 3: 200-fold (2.30 log units) below; the measured number lies above the stated range.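

Exchanging 1-(2-hydroxyethyl)-1H-pyrazol-4-yl for 3-(methylcarbamoyl)phenyl on this aromatic carbon gives, in this assay, a 1200-fold higher number from compound 2 to compound 3 (3.07 log units; beyond the scatter), towards weaker inhibition, so the read-out at this position depends strongly on the group it carries. Nothing available accounts for the size of this step.

On these data alone, this single change replaces the ring and its substituent together, so it remains open which of the two carries the loss. Also open, as far as these compounds go, is how an unsubstituted phenyl, or a 2-aminoethyl chain on the pyrazole in place of 2-hydroxyethyl, would read.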